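From Ethyl to Propyl on One Chain

A few compounds are considered here, and "the series" means these few. Any claim that something is new, unique, unknown or untested is made for them only; others in the source may bear on it.

In a functional assay on MDA-MB-231 cells (Homo sapiens), read by microscopy and transwell migration, with a stated time of 24 h (a higher number here means a weaker inhibitor, a lower number a stronger inhibitor), compound 1 `C=CCn1c(-c2ccc(C)cc2C)cs/c1=N\C(=O)c1ccccc1` gives 456 nM and compound 2 `CCN(C(=O)c1ccccc1)c1nc(-c2ccccc2)cs1` gives 533 nM and these two values lie within the usual scatter of each other. Compound 3 `CCCN(C(=O)c1ccccc1)c1nc(-c2ccccc2)cs1` has not been measured yet. Its structure departs from that of compound 2 by methyl in place of hydrogen on a saturated chain carbon, two bonds along the chain from an amide-type nitrogen and this reads as methyl in place of hydrogen on a saturated chain carbon, two bonds along the chain from an amide-type nitrogen. Going by the values given here, no measured pair shows this change, so the expected step of a 1.0-fold lower number from compound 2 to compound 3 (0.01 log units; within the scatter) stays within the scatter, in neither direction. Compound 3 is expected at 520 nM (estimated range 170 nM to 1600 nM).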

Compound 3, half-maximal inhibitory concentration: 77 nM
The estimate for compound 3 lay 6.8-fold (0.83 log units) above the measured number; measured number below the stated range.
By their numbers in this assay, from the lowest: compound 3; then compounds 1 and 2 (each within the scatter of the next).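

In this assay, lengthening the chain from ethyl to propyl gives a 6.9-fold lower number from compound 2 to compound 3 (0.84 log units; beyond the scatter), so a single methyl on a saturated chain carbon, two bonds along the chain from an amide-type nitrogen, can change the number clearly. Compounds 1 and 2 could not show this, as they differ in more than one place. No measurement here explains why this one added carbon matters so much. As far as these compounds go, whether a butyl chain would lower the number further remains open. So does the effect of an amine at the chain's end.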